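Methyl for methoxy: cytotoxicity notes on the series

This account rests on a few compounds, and the source may have more. Where it says the series, first, only, none or still open, it means among the compounds named here.

The series is followed in a functional assay on MT4 cells (Homo sapiens) for cytotoxicity; on this read-out higher numbers stand for weaker inhibition and lower numbers for stronger inhibition. Compound 2 `COc1cc(C)cc(Sc2cccc(N)c2C#N)c1` carries a methoxy group; in this assay compound 2 gives 10000 nM. Compound 1 `Cc1cc(C)cc(Sc2cccc(N)c2C#N)c1` has methyl in place of methoxy on an aromatic carbon. For compound 1 this assay reports only a limit, > 2000 nM. The step that the limit leaves unreadable from compound 2 to compound 1 cannot be read because of the limit of > 2000 nM in this assay, at which 1 of the 3 values shown sits. Compound 3 `COc1ccc(S(=O)(=O)c2cccc(N)c2C#N)cc1` has a different core; how its core differs from that of compound 2 is not broken down here. For compound 3 this assay again reports only a limit, > 200000 nM, at which (the limit of > 200000 nM in this assay, at which 1 of the 3 values shown sits). Compound 4 `Cc1ccc(S(=O)(=O)c2cccc(N)c2C#N)cc1` is still to be measured in this assay; it stands to compound 3 as compound 1 stands to compound 2, with methyl in place of methoxy on an aromatic carbon. The place is not the same word for word: in compound 4 the change sits para to a large group, whereas in compound 1 it sits meta to a large group and meta to a methyl group, so this is the same kind of change, not the same. Within the data shown here, the only measured example of this change ends at a limit, so its size is unknown here. The expectation for compound 4 rests on compound 3, for which this assay reports only the limit > 200000 nM. Compound 4 is expected to give 200000 nM, between 40000 nM and 600000 nM. The expected step of a number no higher from compound 3 to compound 4 (the limit leaves the size open) is small, and a limit rather than a number is the likely outcome.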

Compound 4, half-maximal inhibitory concentration: > 200000 nM
Compound 4: only a limit was reported; the forecaster's own chance of this, stated with the estimate: 75%; the middle value sits exactly at the limit.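

In this assay the step from compound 3 to compound 4 cannot be read, because both compounds end at a limit and neither gives a number: the limit of > 200000 nM in this assay, at which 2 of the 4 values shown sit. The compounds shown leave open how large the change from methoxy to methyl is on the core of compound 2 and on the core of compound 3, and whether it shifts the read-out at all.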